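Swapping Phenyl for Cyclopropyl on an Alkyne Arm

The source may report more compounds than this note shows. Statements on the series, on what has been measured and on what is new or still open speak of the compounds shown alone.

Of the compounds shown here, two have been tested so far for how strongly they block the growth of a leukaemia cell line. In a functional assay on K562 cells (Homo sapiens) for cytotoxicity, read by thymidine incorporation, with a stated time of 48 h, tested at 10 ug/mL (on this read-out higher numbers stand for more inhibition at the one concentration tested (going by the name of the read-out) and lower numbers for less inhibition), compound 2 `O=c1nc2c(ncn2Cc2ccccc2)c(C#Cc2ccccc2)n1Cc1ccccc1` gives 100%. Compound 1 `O=C1Nc2c(ncn2Cc2ccccc2)C(C#CC2CC2)N1Cc1ccccc1`, which has a different core, gives 98% in this assay; the two numbers lie within the scatter of each other, so neither can be called the stronger. Compound 3 `O=c1nc2c(ncn2Cc2ccccc2)c(C#CC2CC2)n1Cc1ccccc1` keeps the core of compound 2 and changes only the group at the end of the triple bond: cyclopropyl in place of phenyl on a triple-bonded carbon. Going by the values given here, no measured pair shows exactly this step, but compound 1 carries the same cyclopropylethynyl arm and still gives 98%, which suggests the arm does not cost much inhibition. The expected step of a number 5 percentage points lower from compound 2 to compound 3 (within the scatter) is therefore small, downward at most, and likely within the scatter. Compound 3 is estimated to give 95%, between 80% and 100%.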

Compound 3, a percentage reported as inhibition, at one concentration (the size of the read-out at that concentration, not a potency): 97%
For compound 3 the middle estimate is 2 percentage points below the measured one, and the stated range covers the measured number.
By their numbers in this assay, from the lowest: compounds 3, 1 and 2 (each within the scatter of the next).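

In this assay, the direct swap of phenyl for cyclopropyl on a triple-bonded carbon reads as a number 3 percentage points lower from compound 2 to compound 3 (within the scatter), so on this shared core the two groups cannot be told apart. The earlier compounds shown here differ in their cores as well as their arms, whereas this single change shows that the aromatic ring at the end of the triple bond can give way to a small non-aromatic ring with no measurable loss of inhibition at this one concentration. Nothing measured here offers a reason for this result.

All three numbers sit close to the top of the scale, leaving open whether the two groups would differ at lower concentrations. Going by these compounds, it also remains open how an amine or a longer carbon chain at the end of the triple bond would fare.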